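The source may report more compounds than this note shows. Statements on the series, on what has been measured and on what is new or still open speak of the compounds shown alone.

In a functional assay on HCT-116 cells (Homo sapiens) for antiproliferative activity, read by CCK-8 assay, with a stated time of 72 h (on this read-out higher numbers stand for weaker inhibition and lower numbers for stronger inhibition), compound 1 `Nc1ccccc1NC(=O)c1ccc(COc2ccccc2)cc1` gives 4890 nM. Two close relatives keep it company: compound 2 `CCc1ccc(OCc2ccc(C(=O)Nc3ccccc3N)cc2)cc1` gives 4830 nM and compound 3 `Cc1ccc(OCc2ccc(C(=O)Nc3ccccc3N)cc2)cc1` gives 4860 nM. All three values lie within the scatter of one another, so compound 1 has no separate place on these numbers.

The compound still to be measured is compound 4 `COc1ccc(OCc2ccc(C(=O)Nc3ccccc3N)cc2)cc1`. It differs from compound 1 by methoxy in place of hydrogen on an aromatic carbon, which is methoxy in place of hydrogen on an aromatic carbon, para to a large group. Within the data shown here, two measured steps bear on this change, as each also replaces hydrogen on an aromatic carbon. Ethyl gives a 1.0-fold lower number from compound 1 to compound 2 (0.01 log units; within the scatter) and methyl gives a 1.0-fold lower number from compound 1 to compound 3 (0.00 log units; within the scatter). The exchange between those two groups gives a 1.0-fold higher number from compound 2 to compound 3 (0.00 log units; within the scatter). Among the measured compounds shown here, none of the three leaves the scatter, although no measured compound yet carries methoxy, and that limits the comparison.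

On this evidence, no step beyond the scatter is expected in this assay, and no direction is favoured. The expected change is a 1.0-fold lower number from compound 1 to compound 4 (0.02 log units; within the scatter). For compound 4 the estimated value is 4700 nM, with an expected range from 2600 nM to 8000 nM.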

Compound 4, half-maximal inhibitory concentration: 2020 nM
Compound 4: the middle estimate sits 2.3-fold (0.37 log units) above what was measured; measured number outside the range, below it.
By their numbers in this assay, from the lowest: compound 4; then compounds 2, 3 and 1 (each within the scatter of the next).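

In this assay, among these compounds, methoxy is the first group at this position, para to a large group, to move the number beyond the scatter (a 2.4-fold lower number from compound 1 to compound 4 (0.38 log units; beyond the scatter)), whereas the ethyl and methyl steps from compound 1 stayed within it. The comparison with the two substituted compounds points the same way (a 2.4-fold lower number from compound 3 to compound 4 (0.38 log units; beyond the scatter); a 2.4-fold lower number from compound 2 to compound 4 (0.38 log units; beyond the scatter)), so among these four compounds, filling this position is not enough in itself and the shift appears only with methoxy in place of methyl or ethyl. Nothing available explains why methoxy separates from those two groups here.

On these data alone, whether a hydroxy group, an ethoxy group or a chlorine atom at this position would follow methoxy or stay with methyl and ethyl remains open. Also open, as far as these compounds go, is whether methoxy would give a similar step at another place on the same ring, and whether the shift would carry over to any read-out other than this assay.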